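A few compounds are considered here, and "the series" means these few. Any claim that something is new, unique, unknown or untested is made for them only; others in the source may bear on it.

Going by the values given here, in an in vitro ADME assay on microsomes from liver (Homo sapiens) for metabolic stability (on this read-out lower numbers stand for slow clearance and higher numbers for fast clearance), compound 1 `O=C(COCc1ccccc1)N1CCN(c2ccc(Cl)cc2)CC1` gives 290 mL.min-1.g-1 and compound 2 `O=C(COCc1ccccc1)N1CCN(c2ccc(Cl)cc2Cl)CC1` gives 450 mL.min-1.g-1 so compound 1 stands within the scatter of its only measured neighbour. Compound 3 `O=C(COCc1ccncc1)N1CCN(c2ccc(Cl)cc2)CC1` differs from compound 1 by pyridin-4-yl in place of phenyl (pyridin-4-yl in place of phenyl on a saturated chain carbon bound to an oxygen on a saturated carbon) on a saturated chain carbon bound to an oxygen on a saturated carbon. Among the compounds with values here, the one measured step of a 1.6-fold higher number from compound 1 to compound 2 (0.19 log units; within the scatter) is chloro in place of hydrogen on an aromatic carbon, a different change, so it offers no direct guide. A modest move to a lower number in this assay is nonetheless expected, with the estimated step being a 1.7-fold lower number from compound 1 to compound 3 (0.23 log units; within the scatter). Within the data shown here, the size of this step rests on no precedent in the data. For compound 3 the expected value is 170 mL.min-1.g-1 with an estimated range from 70 mL.min-1.g-1 to 380 mL.min-1.g-1 as its bounds.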

Compound 3, intrinsic clearance in microsomes: 17 mL.min-1.g-1
The estimate for compound 3 lay 10-fold (1.00 log units) above the measured number; the whole stated range lies above it.
By their numbers in this assay, from the lowest: compound 3; then compounds 1 and 2 (each within the scatter of the next).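

In this assay, going by these compounds alone, pyridin-4-yl in place of phenyl on a saturated chain carbon bound to an oxygen on a saturated carbon gives a 17-fold lower number from compound 1 to compound 3 (1.23 log units; beyond the scatter), while the only earlier step, a 1.6-fold higher number from compound 1 to compound 2 (0.19 log units; within the scatter), stayed within the scatter. This position is therefore shown to be highly sensitive, although the two groups have the same number of heavy atoms and differ by one ring nitrogen in place of carbon. Nothing available explains the size of this step.

From the compounds shown here alone, it remains open whether pyridin-3-yl or pyrimidin-5-yl on the same carbon would give a similar drop. Going by these compounds, it is also open whether pyridin-4-yl would do the same on the core of compound 2.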